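Removing a ring hydroxy from the sulfamoyl adenosine core

This account rests on a few compounds, and the source may have more. Where it says the series, first, only, none or still open, it means among the compounds named here.

Compound 1: `CSCC[C@H](N)C(=O)NS(=O)(=O)OC[C@H]1OC[C@@H](n2cnc3c(N)ncnc32)[C@H](O)[C@@H]1O`, 5200 nM
Compound 2: `CC(C)C[C@H](N)C(=O)NS(=O)(=O)OC[C@H]1OC[C@@H](n2cnc3c(N)ncnc32)[C@H](O)[C@@H]1O`, 1000 nM

In a functional assay on PBMC cells (Homo sapiens) for inhibition (a higher number here means a weaker inhibitor, a lower number a stronger inhibitor), compound 2 stands lowest of the two numbers measured, and its nearest neighbour is compound 1. Among the compounds with values here, the one measured step, a 5.2-fold lower number from compound 1 to compound 2 (0.72 log units; beyond the scatter), concerns the side chain only. Compound 3, `CC(C)C[C@H](N)C(=O)NS(=O)(=O)OC[C@H]1OC[C@@H](n2cnc3c(N)ncnc32)C[C@@H]1O`, changes the core instead: hydrogen in place of hydroxy on a saturated ring carbon. Within the data shown here, no measured step bears on this change, so the direction is not anchored by data. A step is nevertheless expected, a 3.0-fold higher number from compound 2 to compound 3 (0.48 log units; beyond the scatter), towards a higher number. Compound 3 is therefore estimated at 3000 nM, in the range 800 nM to 15000 nM.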

Compound 3, half-maximal inhibitory concentration: 6800 nM
Compound 3: middle estimate off by 2.3-fold (0.36 log units), on the low side; low and high end bracket the measured number.
By their numbers in this assay, from the lowest: compound 2; then compounds 1 and 3 (each within the scatter of the next).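

In this assay, the hydroxy on this saturated ring carbon proves to count: hydrogen in its place gives a 6.8-fold higher number from compound 2 to compound 3 (0.83 log units; beyond the scatter), a step beyond the scatter. Within the data shown here, this is the first measured change to the shared core, and it shows that the core, not only the side chain, moves the number. No measurement at hand gives a reason for this step.

The compounds shown leave open whether a methoxy group or a fluorine on this carbon would keep the number of compound 2. They also leave open whether the step would be similar with the (methylsulfanyl)methyl side chain of compound 1.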